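Trifluoromethoxy in place of trifluoromethyl on compound 3

The source may report more compounds than this note shows. Statements on the series, on what has been measured and on what is new or still open speak of the compounds shown alone.

Compound 1 `CC(O)(COc1ccc(S(F)(F)(F)(F)F)cc1)C(=O)Nc1cc(C(F)(F)F)cc(C(F)(F)F)c1`: 6500 nM
Compound 2 `CC(O)(CS(=O)(=O)c1ccc(S(F)(F)(F)(F)F)cc1)C(=O)Nc1ccc(C#N)cc1C(F)(F)F`: 25600 nM
Compound 3 `CC(O)(CS(=O)(=O)c1ccccc1C(F)(F)F)C(=O)Nc1cccc(S(F)(F)(F)(F)F)c1`: 27300 nM

All three values come from a functional assay on DU-145 cells (Homo sapiens) for antiproliferative activity, read by propidium iodide staining, with a stated time of 96 h; on this read-out lower numbers stand for stronger inhibition and higher numbers for weaker inhibition. Compound 3 lies within the scatter of compound 2, while its number is higher than that of compound 1 by a margin beyond the scatter. The next compound, compound 4 `CC(O)(CS(=O)(=O)c1ccccc1OC(F)(F)F)C(=O)Nc1cccc(S(F)(F)(F)(F)F)c1`, carries trifluoromethoxy in place of trifluoromethyl on an aromatic carbon, ortho to a large group (trifluoromethoxy in place of trifluoromethyl on an aromatic carbon). Among the measured compounds shown here, no measured pair differs in one place only, so the data offer no precedent for this change. The expected step of a 1.2-fold lower number from compound 3 to compound 4 (0.09 log units; within the scatter) in this assay stays within the scatter, with no clear direction. For compound 4 the estimated value is 22000 nM, with an expected range of 10000 nM to 45000 nM.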

Compound 4, half-maximal inhibitory concentration: 29100 nM
Estimate against measurement, compound 4: 1.3-fold (0.12 log units) below; measured number inside the range.
By their numbers in this assay, from the lowest: compound 1; then compounds 2, 3 and 4 (each within the scatter of the next).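

The exchange of trifluoromethyl for trifluoromethoxy on this aromatic carbon gives a 1.1-fold higher number from compound 3 to compound 4 (0.03 log units; within the scatter) in this assay and is the first change in one place among these compounds. At this position, ortho to a large group, the two substituents cannot be told apart on this read-out. No available measurement explains this result.

As far as these compounds go, whether a methoxy group, a chlorine atom or an amine on this aromatic carbon would read the same remains open. So does whether the same exchange would behave alike elsewhere on the ring.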